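A few compounds are considered here, and "the series" means these few. Any claim that something is new, unique, unknown or untested is made for them only; others in the source may bear on it.

Measured compounds:
- compound 1, `CN(C)CC[C@H](CSc1ccccc1)Nc1ccc(S(=O)(=O)NC(=O)c2ccc(N3CCN(Cc4ccccc4-c4ccc(Cl)cc4)CC3)cc2)cc1OC(F)(F)F` — in an assay on isolated protein for displacement of a labelled ligand from Apoptosis regulator Bcl-2 (Homo sapiens), read by fluorescence polarization (on this read-out higher numbers stand for weaker inhibition and lower numbers for stronger inhibition), compound 1 gives < 1 nM, which is a limit of the assay.
- compound 2, `CN(C)CC[C@H](CSc1ccccc1)Nc1ccc(S(=O)(=O)NC(=O)c2ccc(N3CCN(CC4=C(c5ccc(Cl)cc5)CCOC4)CC3)cc2)cc1[N+](=O)[O-]` — in this assay compound 2 gives 2.4 nM.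
- compound 3, `CN(C)CC[C@H](CSc1ccccc1)Nc1ccc(S(=O)(=O)NC(=O)c2ccc(N3CCN(CC4=C(c5ccc(Cl)cc5)CCCC4)CC3)cc2)cc1[N+](=O)[O-]` — in this assay compound 3 gives < 1 nM, again a limit of the assay.

Compound 1 therefore stands at the strongest end of what this assay can report: its value is not a number but (the limit of < 1 nM in this assay, at which 2 of the 3 values shown sit). Compound 2 is the only one of the three with a measured number; compound 3 shares the limit with compound 1. No single change between two measured compounds is available here, so nothing measured tells how the part of the structure changed below behaves.

Compound 4, `CN(C)CC[C@H](CSc1ccccc1)Nc1ccc(S(=O)(=O)NC(=O)c2ccc(N3CCN(Cc4ccccc4-c4ccc(Cl)cc4)CC3)cc2)cc1S(=O)(=O)C(F)(F)F`, differs from compound 1 in one place: (trifluoromethyl)sulfonyl in place of trifluoromethoxy on an aromatic carbon. Since compound 1 gives only a limit, any shift that keeps compound 4 at or near that limit would be invisible. The expectation is that compound 4 stays close to compound 1, with the step of a number no lower from compound 1 to compound 4 (the limit leaves the size open) no larger than the usual scatter. Compound 4 is estimated at 1 nM, within a range from 0.3 nM to 3 nM.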

Compound 4, inhibition constant: < 1 nM
Compound 4 ended at the assay's limit; the forecaster's own chance of this, stated with the estimate: 55%; the middle value sits exactly at the limit.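

Putting (trifluoromethyl)sulfonyl in place of trifluoromethoxy gives no readable step between compound 1 and compound 4, since both results are limits and not numbers: the limit of < 1 nM in this assay, at which 3 of the 4 values shown sit.

On these data alone, whether either of these two groups gives stronger inhibition than the other stays open.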